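From Compound 1 to Compound 3: Adding a 3-Methylbut-2-en-1-yl Group

The compounds below may be only part of what the source reports. "The series", "measured", "known", "first", "only" and "open" are said of these compounds alone.

Compound 1 (`CC(=O)c1c(O)cc(O)c(CC=C(C)C)c1O`) is the starting point here. Within the data shown here, in a functional assay on HL-60 cells (Homo sapiens) for cytotoxicity, read by XTT assay, with a stated time of 72 h (a higher number here means a weaker inhibitor, a lower number a stronger inhibitor), compound 1 gives 32000 nM, which is the only exact number available so far. Compound 2 (`CC(=O)c1c(O)cc(O)c2c1OC(C)(C)CC2`) gives > 100000 nM, and this value is a limit of the assay and not a number.

Compound 3 (`CC(=O)c1c(O)c(CC=C(C)C)c(O)c(CC=C(C)C)c1O`) has not yet been measured. It differs from compound 1 in one place: 3-methylbut-2-en-1-yl in place of hydrogen on an aromatic carbon. In plain terms, a 3-methylbut-2-en-1-yl group takes the place of a hydrogen on an aromatic carbon, and the rest of the structure stays the same.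

Among the measured compounds shown here, no two measured compounds differ in just one place, so the data give no direct measure of what this kind of change does. The expectation is therefore cautious: a modest move toward a lower number in this assay, meaning a somewhat stronger compound, and one that may barely clear the usual scatter. The expected size of the change is a 2.3-fold lower number from compound 1 to compound 3 (0.36 log units; beyond the scatter). For compound 3 the estimated value is 14000 nM, with an expected range of 4500 nM to 40000 nM.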

Compound 3, half-maximal inhibitory concentration: > 100000 nM
Compound 3 ended at the assay's limit (the forecaster's own chance of this, stated with the estimate: 7%); middle value at least 7.1-fold (0.85 log units) from the limit.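

Among these compounds, this is the first direct reading of a change at this position, the aromatic carbon ortho to two hydroxy groups and para to a third: placing a 3-methylbut-2-en-1-yl group there gives an at least 3.1-fold higher number from compound 1 to compound 3 (0.49 log units; beyond the scatter), so the change makes the compound weaker, not stronger. In this assay compound 3 gives > 100000 nM, which is a limit of the assay and not a number. The step therefore fixes only a direction and a minimum size, and its full size cannot be read because the result sits at the end of the measurable range: the limit of > 100000 nM in this assay, at which 2 of the 3 values shown sit.

Going by these compounds, what stays open is whether this weakening belongs to the 3-methylbut-2-en-1-yl group itself or would follow from almost any group on this carbon, and a methyl group, an amine or a carboxylic acid at the same place would help to separate those two readings. On these data alone, it is also open whether a longer chain here would behave like the 3-methylbut-2-en-1-yl group, and whether the same change would have the same effect on any other core.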